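Benzyloxy flavonols: cytotoxicity notes ahead of compound 4

The source may report more compounds than this note shows. Statements on the series, on what has been measured and on what is new or still open speak of the compounds shown alone.

Measured so far in an ADME assay on Huh-5-2 cells (Homo sapiens) for cytotoxicity, read by WST assay, with a stated time of 3 days; on this read-out higher numbers stand for lower toxicity in this test and lower numbers for higher toxicity in this test:
compound 1 `O=c1c(OCc2cccc(Cl)c2)c(-c2ccccc2)oc2cc(O)cc(O)c12`: 46000 nM
compound 2 `N#Cc1cccc(COc2c(-c3ccccc3)oc3cc(O)cc(O)c3c2=O)c1`: 21000 nM
compound 3 `O=c1c(OCc2cccc([N+](=O)[O-])c2)c(-c2ccccc2)oc2cc(O)cc(O)c12`: 31000 nM

Compound 3 gives the second highest of the three numbers in this assay. Its nearest neighbour is compound 2 with a 1.5-fold higher number from compound 2 to compound 3 (0.17 log units; within the scatter), and the remaining comparison is a 1.5-fold lower number from compound 1 to compound 3 (0.17 log units; within the scatter); both are within the scatter, so on these numbers compound 3 sits in the same band as the other two. Among the compounds with values here, the only step in the set that reaches beyond the scatter is a 2.2-fold lower number from compound 1 to compound 2 (0.34 log units; beyond the scatter), and that one is modest.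

Compound 4 `Cc1ccc(COc2c(-c3ccccc3)oc3cc(O)cc(O)c3c2=O)cc1` differs from compound 3 by 4-methylphenyl in place of 3-nitrophenyl on a saturated chain carbon bound to an oxygen on an aromatic ring. All three measured steps swap one substituent for another on the same benzyl ring, and all stay small; none introduces a methyl group and none places a substituent as in the 4-methylphenyl group, so they bear on the change only as a general indication that such swaps have moved the numbers little in this series.

For compound 4 the expectation is therefore no step beyond the scatter, a 1.1-fold higher number from compound 3 to compound 4 (0.05 log units; within the scatter), with the estimate in this assay at 35000 nM and a range of 15000 nM to 80000 nM.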

Compound 4, half-maximal cytotoxic concentration: 40000 nM
Compound 4: middle estimate off by 1.1-fold (0.06 log units), on the low side; the range from low to high includes it.
By their numbers in this assay, from the lowest: compounds 2, 3, 4 and 1 (each within the scatter of the next, the first and the last beyond it).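

At the saturated chain carbon bound to an oxygen on an aromatic ring, this assay now covers an all-carbon group: 4-methylphenyl, which has no hydrogen-bond acceptors where 3-nitrophenyl has two, gives a 1.3-fold higher number from compound 3 to compound 4 (0.11 log units; within the scatter). The comparisons with the other two groups read the same way, with a 1.9-fold higher number from compound 2 to compound 4 (0.28 log units; within the scatter) for 3-cyanophenyl and a 1.2-fold lower number from compound 1 to compound 4 (0.06 log units; within the scatter) for 3-chlorophenyl, so compound 4 lies within the scatter of all three earlier compounds, even though the step between compound 1 and compound 2, a 2.2-fold lower number from compound 1 to compound 2 (0.34 log units; beyond the scatter), lies beyond it. This change of group therefore leaves the number in the same band as the earlier compounds, and nothing available bears on why the numbers stay so close.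

Compound 4 alters both the substituent and its place on the benzyl ring, so the contribution of each cannot be told apart from these compounds. Also open, from the compounds shown here alone, is whether the band holds for a benzyl ring carrying an amine or a carboxylic acid, or for a longer chain in place of the single saturated chain carbon.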